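Trifluoromethyl on the aryl ring of the lactam series

This account rests on a few compounds, and the source may have more. Where it says the series, first, only, none or still open, it means among the compounds named here.

Measured so far:
compound 1, `COc1ccc(/C=C/C2CC(=O)C=CO2)cc1OC`, 145 uM
compound 2, `COc1ccc(C2CC(=O)C=CO2)cc1`, 197 uM
compound 3, `O=C1C=CCC(/C=C/c2ccccc2)N1`, > 1250 uM

In a functional assay on 786-0 cells (Homo sapiens) for inhibition, read by sulforhodamine B assay, with a stated time of 48 h (on this read-out higher numbers stand for weaker inhibition of growth and lower numbers for stronger inhibition of growth), compound 1 gives 145 uM and compound 2 gives 197 uM. For compound 3 only a limit is reported, > 1250 uM, which is the limit of > 1250 uM in this assay, at which 1 of the 3 values shown sits. Compound 4, `O=C1C=CCC(/C=C/c2ccccc2C(F)(F)F)N1`, differs from compound 3 by trifluoromethyl in place of hydrogen on an aromatic carbon. Among the compounds with values here, no measured pair tells how such a change moves growth inhibition, so no size of step is known. Compound 4 is expected to sit near the same limit, with the step of a number no higher from compound 3 to compound 4 (the limit leaves the size open) likely no larger than the scatter. Compound 4 is therefore estimated at 1250 uM, within 400 uM to 3000 uM.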

Compound 4, concentration for growth inhibition (reported as GI): 123 uM
The estimate for compound 4 lay 10-fold (1.01 log units) above the measured number, and the stated range ends above it.
By their numbers in this assay, from the lowest: compounds 4, 1 and 2 (each within the scatter of the next). At a limit, above all of these: compound 3.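

In this assay, trifluoromethyl in place of hydrogen on an aromatic carbon, ortho to a group of 9 heavy atoms, gives an at least 10-fold lower number from compound 3 to compound 4 (1.00 log units; beyond the scatter). Within the data shown here, this is the first measured pair, and it shows that growth inhibition responds to a change at this position. The true size of the step stays open because compound 3 stands at a limit: the limit of > 1250 uM in this assay, at which 1 of the 4 values shown sits.

The compounds shown leave open whether a chlorine, a methoxy group or an amine on this aromatic carbon would move the number as trifluoromethyl does. They also leave open whether trifluoromethyl would do the same on another carbon of the ring.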